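Phenyl for Pyridyl on a Biaryl Amide Antagonist

This account rests on a few compounds, and the source may have more. Where it says the series, first, only, none or still open, it means among the compounds named here.

Compound 1 `CC(C)(C)c1ccc(NC(=O)N2CCN(c3ccccn3)CC2)cc1`: 150 nM
Compound 2 `CC(C)(C)c1ccc(NC(=O)c2ccc(-c3ccccn3)cc2)cc1`: 31 nM

Of the compounds shown here, two have so far been measured in a functional assay on Dorsal root ganglion for antagonist activity at transient receptor potential cation channel subfamily V member 1 (Rattus norvegicus); on this read-out lower numbers stand for stronger inhibition and higher numbers for weaker inhibition. Compound 1 `CC(C)(C)c1ccc(NC(=O)N2CCN(c3ccccn3)CC2)cc1` gives 150 nM, whereas compound 2 `CC(C)(C)c1ccc(NC(=O)c2ccc(-c3ccccn3)cc2)cc1` gives 31 nM. Of these two numbers, compound 2 holds the lower one, and its gap to compound 1 lies beyond the usual scatter of this kind of measurement.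

Compound 3 `CC(C)(C)c1ccc(NC(=O)c2ccc(-c3ccccc3)cc2)cc1` has not yet been measured. It differs from compound 2 in a single place: phenyl in place of pyridin-2-yl on an aromatic carbon. Going by the values given here, no pair of measured compounds shows a step of this kind, so any expectation rests on the standing of compound 2 alone. The expected step, a 1.8-fold higher number from compound 2 to compound 3 (0.25 log units; within the scatter), is a modest weakening, though an outcome within the scatter would not be surprising. Compound 3 is therefore expected to give about 55 nM in this assay, with a range from 15 nM to 200 nM.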

Compound 3, half-maximal inhibitory concentration: 3600 nM
Compound 3: the middle estimate sits 65-fold (1.82 log units) below what was measured, outside the stated range (above it).
By their numbers in this assay, from the lowest: compound 2; then compound 1; then compound 3.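

In this assay, replacing pyridin-2-yl with phenyl on this aromatic carbon gives a 120-fold higher number from compound 2 to compound 3 (2.06 log units; beyond the scatter), so this position does not tolerate every six-membered aromatic ring equally. The entering and leaving groups have the same number of heavy atoms, and the change swaps the ring nitrogen for carbon and removes the group's one hydrogen-bond acceptor, yet that small edit comes with a step of this size. Nothing presented here accounts for why this exchange has so large an effect.

As far as these compounds go, it remains open whether pyridin-3-yl or pyridin-4-yl would match pyridin-2-yl at this place, which would show whether the location of the ring nitrogen matters. From the compounds shown here alone, it is also open whether a phenyl ring carrying a methoxy group or an amine could recover what plain phenyl gives up.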